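Swapping a fluorophenyl for pyridyl on a pyrrolidine amide

This account rests on a few compounds, and the source may have more. Where it says the series, first, only, none or still open, it means among the compounds named here.

Measured compounds:
compound 1 `O=C(CCc1ccc(-c2cccc(F)c2)cc1)N1CCCC1` — 1800 nM
compound 2 `CCCc1cccc(CCCCCCC(=O)N2CCCC2)c1` — > 100000 nM

The assay here is an assay on HEK293 cells for inhibition of N-acylethanolamine-hydrolyzing acid amidase (Rattus norvegicus), read by LC-MS, with a stated time of 30 min; a lower number here means a stronger inhibitor, a higher number a weaker inhibitor. Of the compounds shown here, two have been tested. Among the measured compounds shown here, compound 1 `O=C(CCc1ccc(-c2cccc(F)c2)cc1)N1CCCC1` gives 1800 nM in this assay, and that is the only actual number available, so it stands alone. Compound 2 `CCCc1cccc(CCCCCCC(=O)N2CCCC2)c1` gives > 100000 nM, which is a limit of the assay rather than a number. Compound 2 sits at the limit of > 100000 nM in this assay, at which 1 of the 2 values shown sits. For the measured compounds named here, because it is a limit, no step between compound 1 and compound 2 can be computed, and the two compounds also differ in more than one place, so they say little about each other beyond the fact that compound 2 is weaker than the assay can resolve.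

The next compound, compound 3 `O=C(CCc1ccc(-c2ccccn2)cc1)N1CCCC1`, is compound 1 with one change: pyridin-2-yl in place of 3-fluorophenyl on an aromatic carbon. The shared core, the pyrrolidine amide and the ring it hangs from, stays as it is. Going by the values given here, with no measured step of this kind to lean on, the expectation is a modest change, if any, and a weakening seems slightly more likely than a gain. The estimated step of a 1.9-fold higher number from compound 1 to compound 3 (0.29 log units; within the scatter) from compound 1 to compound 3 stays small. Compound 3 is expected to give about 3500 nM, within a range from 1000 nM to 15000 nM.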

Compound 3, half-maximal inhibitory concentration: > 100000 nM
Compound 3 was reported as a limit (the forecaster's own chance of this, stated with the estimate: 10%); at least 28-fold (1.45 log units) between middle value and limit.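

In this assay, among the compounds shown here, pyridin-2-yl in place of 3-fluorophenyl on an aromatic carbon gives an at least 55-fold higher number from compound 1 to compound 3 (1.74 log units; beyond the scatter), the first step here that can be read between two compounds differing in one place, and it shows that the group at this position is not freely exchangeable. From the compounds shown here alone, compound 3 gives > 100000 nM, which is a limit of the assay and not a number, so the step marks only the smallest gap consistent with the data and its true size stays unknown. With this result, compound 3 joins compound 2 at the same limit: the limit of > 100000 nM in this assay, at which 2 of the 3 values shown sit.

The swap removes the fluorine and brings in a ring nitrogen at the same time, and the compounds shown do not separate these two changes or say whether the position of that nitrogen matters. An unsubstituted phenyl, a pyridin-3-yl or a pyridin-4-yl group at this position is not among the compounds shown, so which part of the change accounts for the drop remains open.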